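Hydroxy removal from compound 3 in an inactive series

The source may hold more compounds than are shown below. What is called first, only, known or untested is meant among the compounds shown, and "the series" means these compounds.

In a functional assay on A2780 cells (Homo sapiens) for cytotoxicity, read by MTT assay, with a stated time of 24 h (a higher number here means a weaker inhibitor, a lower number a stronger inhibitor), compound 1 `C[C@@H]1O[C@@]1(C)C(=O)C[C@H]1[C@](C)(O)CC[C@@]2(O)C(C)(C)CCC[C@]12C` gives > 10000 nM as a limit, not a number. Compound 2 `C[C@H]1O[C@]1(C)C(=O)C[C@H]1[C@](C)(O)CC[C@@]2(O)C(C)(C)CCC[C@]12C` gives > 10000 nM as a limit too. Compound 3 `C/C=C(\C)C(=O)C[C@@H]1[C@@]2(C)[C@@H](O)CCC(C)(C)[C@]2(O)CC[C@@]1(C)O` gives > 10000 nM as a limit as well, so it holds no rank within the series. With the limit of > 10000 nM in this assay, at which 3 of the 3 values shown sit, as the whole record, no order of potency can be read.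

Compound 4 `C/C=C(\C)C(=O)C[C@H]1[C@](C)(O)CC[C@@]2(O)C(C)(C)CCC[C@]12C` carries hydrogen in place of hydroxy on a saturated ring carbon of compound 3 (hydrogen in place of hydroxy on a saturated ring carbon). Among the compounds with values here, the one measured step (a step that the two limits leave unreadable from compound 1 to compound 2) has no readable size and concerns only the fact that compounds 1 and 2 differ only in the configuration as drawn. Within the data shown here, no measured step touches this hydroxy, so the data give no size to carry over. A clear gain in potency is not expected, and a further limit reading is the likeliest result. The expected step (a step that the limit leaves unreadable from compound 3 to compound 4) is none beyond the scatter. In this assay compound 4 is estimated at 15000 nM with an expected range from 6000 nM to 40000 nM as its ends.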

Compound 4, half-maximal inhibitory concentration: > 10000 nM
Compound 4: only a limit was reported (the forecaster's own chance of this, stated with the estimate: 75%); the middle value lies beyond the limit too.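

Compound 4 also reads as a limit in this assay, so its steps from compound 1, compound 2 and compound 3 cannot be read. Left open is whether hydroxy removal or 2,3-dimethyloxiran-2-yl exchange alters potency at all: no compound shown gives a number.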